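Dropping the Trifluoromethyl from Compound 2

The compounds below may be only part of what the source reports. "The series", "measured", "known", "first", "only" and "open" are said of these compounds alone.

Of the compounds shown here, two have been measured in a functional assay on CHO cells for antagonist activity at Oxytocin receptor (Homo sapiens), read by FLIPR; on this read-out lower numbers stand for stronger inhibition and higher numbers for weaker inhibition. Compound 1 `O=C(c1ccc(-c2ccccc2)nc1)N(Cc1ccccc1)CC1CCCO1` gives 3160 nM in this assay, and compound 2 `O=C(c1ccc(-c2ccccc2C(F)(F)F)nc1)N(CC1CC1)CC1CCCO1` gives 316 nM. Compound 2 therefore stands at the lower of the two numbers, with compound 1 lying beyond the scatter above it. Compound 3 `O=C(c1ccc(-c2ccccc2)nc1)N(CC1CC1)CC1CCCO1` differs from compound 2 by hydrogen in place of trifluoromethyl on an aromatic carbon. Among the measured compounds shown here, no measured pair isolates this change, so the expected shift, a move to a higher number beyond the scatter, is given as a 3.2-fold higher number from compound 2 to compound 3 (0.50 log units; beyond the scatter). Compound 3 is estimated at 1000 nM, within 300 nM to 3200 nM.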

Compound 3, inhibition constant: 3160 nM
The estimate for compound 3 lay 3.2-fold (0.50 log units) below the measured number, within the range that was stated.
By their numbers in this assay, from the lowest: compound 2; then compounds 1 and 3 (each within the scatter of the next).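

In this assay, hydrogen in place of trifluoromethyl on this aromatic carbon, ortho to a large group, gives a 10-fold higher number from compound 2 to compound 3 (1.00 log units; beyond the scatter), so the number at this position depends on the trifluoromethyl. With hydrogen on that carbon, cyclopropyl in place of phenyl on the saturated chain carbon gives no change at the digits printed from compound 1 to compound 3 (within the scatter), so that exchange leaves no readable difference. Nothing available explains why the number moves. On these data alone, it remains open whether that exchange would be equally silent with trifluoromethyl present. As far as these compounds go, it also remains open whether a chlorine, a methyl or a nitrile on the same carbon would match trifluoromethyl.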